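Swapping a urea for an amide on a leukotriene antagonist

The compounds below may be only part of what the source reports. "The series", "measured", "known", "first", "only" and "open" are said of these compounds alone.

Measured compounds:
Compound 1 `COc1cc(C(=O)O)ccc1Cc1nn(C)c2ccc(NC(=O)OC3CCCC3)cc12` gives 160 nM in an assay on lung parenchyma for displacement of a labelled ligand from cysteinyl leukotriene receptor 1 (Cavia porcellus); a lower number here means a stronger inhibitor, a higher number a weaker inhibitor.
Compound 2 `COc1cc(C(=O)O)ccc1Cn1ccc2ccc(NC(=O)OC3CCCC3)cc21` gives 160 nM in this assay.
Compound 3 `COc1cc(C(=O)NS(=O)(=O)c2ccccc2C)ccc1Cc1cn(C)c2ccc(NC(=O)NC3CCCC3)cc12` gives 1.4 nM in this assay.

Compound 3 holds the lowest number of the three by a wide margin, far beyond the scatter relative to both compound 1 and compound 2. Compound 4 `COc1cc(C(=O)NS(=O)(=O)c2ccccc2C)ccc1Cc1cn(C)c2ccc(NC(=O)CC3CCCC3)cc12` differs from it only in the change (cyclopentylmethyl in place of cyclopentylamino on a carbonyl carbon). The counted difference shows that the hydrogen-bond donor of the cyclopentylamino group is gone once cyclopentylmethyl takes its place. For the measured compounds named here, no measured pair shows what that swap does here, so the expectation rests on compound 3 alone. Compound 4 is expected to stay potent, with a modest rise in number from compound 3, roughly a 2.1-fold higher number from compound 3 to compound 4 (0.33 log units; beyond the scatter), giving an estimated 3 nM within 1 nM to 12 nM.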

Compound 4, inhibition constant: 0.5 nM
Compound 4: the middle estimate sits 6.0-fold (0.78 log units) above what was measured; measured number below the stated range.
By their numbers in this assay, from the lowest: compound 4; then compound 3; then compounds 1 and 2 (each within the scatter of the next).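

Putting cyclopentylmethyl in place of cyclopentylamino on this carbonyl carbon gives a 2.8-fold lower number from compound 3 to compound 4 (0.45 log units; beyond the scatter) in this assay. The hydrogen-bond donor of the cyclopentylamino group is therefore not needed for a low number in this pair, since compound 4 lacks it and still reads lower. Nothing measured here explains why the number falls.

This rests on a single pair. From the compounds shown here alone, it remains open how a larger ring, as in cyclohexylmethyl, or an open chain such as n-pentyl would read on the same carbonyl carbon.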